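The source may report more compounds than this note shows. Statements on the series, on what has been measured and on what is new or still open speak of the compounds shown alone.

The study compares three measured compounds and one that awaits measurement. Compound 1 `COc1cc2occ(-c3csc4ccccc34)c(=O)c2c(OC)c1OC` gives 740 nM in a functional assay on MCF7 cells (Homo sapiens) for antiproliferative activity, read by sulforhodamine B assay, with a stated time of 72 h; on this read-out lower numbers stand for stronger inhibition and higher numbers for weaker inhibition. Compound 2 `CCOc1c(OC)cc2occ(-c3csc4ccccc34)c(=O)c2c1OC` differs from compound 1 by methyl in place of hydrogen on a saturated chain carbon bound to an oxygen on an aromatic ring; in this assay compound 2 gives 4000 nM. The step of a 5.4-fold higher number from compound 1 to compound 2 (0.73 log units; beyond the scatter) is the change seen across this pair. Compound 3 `COc1ccc(O)c(C(=O)/C=C/c2csc3ccccc23)c1` carries a core unlike that of compound 1, and the difference between the two cores is not broken down here; in this assay compound 3 gives 750 nM, which lies within the scatter of the value of compound 1. Compound 4 `CCOc1ccc(O)c(C(=O)/C=C/c2csc3ccccc23)c1` arises from compound 3 by methyl in place of hydrogen on a saturated chain carbon bound to an oxygen on an aromatic ring, the same change, at the same place, that turned compound 1 into compound 2. Because a 5.4-fold higher number from compound 1 to compound 2 (0.73 log units; beyond the scatter) lies beyond the scatter, a step of similar size is expected here, although that step has been seen only once and on a different core, so the range is kept wide. The expected step is a 3.3-fold higher number from compound 3 to compound 4 (0.52 log units; beyond the scatter). Compound 4 is therefore estimated at 2500 nM in this assay, with an expected range from 900 nM to 7000 nM.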

Compound 4, half-maximal inhibitory concentration: 7500 nM
For compound 4 the middle estimate is 3.0-fold (0.48 log units) below the measured one; the measured number lies above the stated range.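

On the core of compound 3, the change from methoxy to ethoxy gives a 10-fold higher number from compound 3 to compound 4 (1.00 log units; beyond the scatter) in this assay and so runs in the same direction as on the core of compound 1. The two steps do not differ beyond what repeated measurement allows, so on these two cores both the direction and the size of the change carry over: the same change on two cores in this assay, a 5.4-fold higher number (0.73 log units; beyond the scatter) from compound 1 to compound 2 and a 10-fold higher number (1.00 log units; beyond the scatter) from compound 3 to compound 4, 1.9-fold (0.27 log units) apart, within the scatter of two such steps. Within the data shown here, this rests on only two pairs in a single assay, and it shows neither that the change would behave alike on a further core nor why the number rises.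

The compounds shown leave open whether the rise continues with a longer chain such as propyl, and what a branched isopropyl group or an amine at the end of the chain would do on either core. They also leave open whether the same step appears in cell lines other than this one.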